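A few compounds are considered here, and "the series" means these few. Any claim that something is new, unique, unknown or untested is made for them only; others in the source may bear on it.

In an assay on CHO cells for displacement of a labelled ligand from adenosine receptor A2b (Homo sapiens), read by radioligand binding (on this read-out higher numbers stand for weaker inhibition and lower numbers for stronger inhibition), compound 1 `CC(=O)Oc1cccc2cc(-c3ccccc3)c(=O)oc12` gives only a limit of the assay, > 30000 nM. Compound 2 `CC(=O)Oc1ccc(-c2cc3ccc(OC(C)=O)c(OC(C)=O)c3oc2=O)cc1` likewise reaches only a limit in this assay, > 30000 nM. Compound 3 `CC(=O)Oc1ccc(-c2cc3cccc(OC(C)=O)c3oc2=O)cc1OC(C)=O` also stands at a limit in this assay, > 30000 nM. Its place among the numbers shown is therefore the edge of the range, since all three values rest there (the limit of > 30000 nM in this assay, at which 3 of the 3 values shown sit). Compound 4 `CC(=O)Oc1ccc(-c2cc3ccc(OC(C)=O)c(OC(C)=O)c3oc2=O)cc1OC(C)=O` differs from compound 3 by acetoxy in place of hydrogen on an aromatic carbon. Among the measured compounds shown here, no step between measured compounds is known, so nothing points away from the limit. For compound 4 the expected step that the limit leaves unreadable from compound 3 to compound 4 is none beyond the scatter. Compound 4 is thus estimated in this assay at 50000 nM, between 20000 nM and 150000 nM.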

Compound 4, inhibition constant: > 30000 nM
Compound 4 gave a limit, no number; the forecaster's own chance of this, stated with the estimate: 90%; the middle value does not contradict the limit.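

Among the compounds shown here, compound 2, compound 3 and compound 4 all stand at a limit, and no step to compound 4 can be read from either of the other two. In this assay the compounds shown leave open whether acetoxy in place of hydrogen on an aromatic carbon changes the inhibition constant at all.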